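This account rests on a few compounds, and the source may have more. Where it says the series, first, only, none or still open, it means among the compounds named here.

Compound 1 `Nc1ccc(C(=O)/C=C/c2ccco2)cc1` and compound 2 `O=C(/C=C/c1ccco1)c1ccc(NC(=O)c2cccs2)cc1` share a core in which a furan-bearing enone is joined to an aromatic ring that carries a nitrogen. In a functional assay on DLD-1 cells (Homo sapiens) for cytotoxicity, read by resazurin assay, with a stated time of 48 h (on this read-out lower numbers stand for an effect already at smaller amounts and higher numbers for an effect only at larger amounts of compound), compound 1 gives 31000 nM, and compound 2 gives 56000 nM. Within the data shown here, the only step measured so far, a 1.8-fold higher number from compound 1 to compound 2 (0.26 log units; within the scatter), replaces hydrogen on that nitrogen with a (thiophen-2-yl)carbonyl group. Among the two numbers known, compound 2 has the highest, with compound 1 as its nearest neighbour at a distance within the scatter.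

Compound 3 `O=C(/C=C/c1ccco1)c1ccc(NC(=O)c2ccccc2)cc1` differs from compound 2 in one place: phenyl in place of thiophen-2-yl on a carbonyl carbon. Among the measured compounds shown here, no measured step involves this exact exchange, so the expectation must lean on the neighbouring pair, where even adding the whole (thiophen-2-yl)carbonyl group moved the number only within the scatter. A swap of one aromatic ring for another of similar size is therefore expected to give a step of a 1.1-fold lower number from compound 2 to compound 3 (0.05 log units; within the scatter), that is, no change beyond the scatter. Compound 3 is accordingly estimated at 50000 nM, with a likely range from 20000 nM to 125000 nM.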

Compound 3, half-maximal effective concentration: 69000 nM
The estimate for compound 3 lay 1.4-fold (0.14 log units) below the measured number, within the range that was stated.
By their numbers in this assay, from the lowest: compounds 1, 2 and 3 (each within the scatter of the next, the first and the last beyond it).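

In this assay, the exchange on the carbonyl carbon swaps a five-membered aromatic ring with one hetero atom for a six-membered aromatic ring of carbon only and gives a 1.2-fold higher number from compound 2 to compound 3 (0.09 log units; within the scatter), so at this place the two rings cannot be told apart by their numbers. Among these compounds, the benzoyl group on the nitrogen does give the first step that clears the scatter, a 2.2-fold higher number from compound 1 to compound 3 (0.35 log units; beyond the scatter), yet this modest step should not be read as something special to phenyl, since compound 2 and compound 3 remain within the scatter of each other. No measurement available here explains these numbers.

As far as these compounds go, it remains open whether an aromatic ring on the carbonyl carbon matters at all, a question that a plain methyl or a cyclohexyl group in its place would address. From the compounds shown here alone, it is equally open whether an amine, a carboxylic acid or a methoxy group carried on the phenyl ring of compound 3 would move the number beyond the scatter, and in which direction.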